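The source may report more compounds than this note shows. Statements on the series, on what has been measured and on what is new or still open speak of the compounds shown alone.

Measured compounds:
- compound 1, `CC(=O)CCSC(=S)NCc1cccnc1`: 1120 nM
- compound 2, `O=C(O)CCSC(=S)NCc1cccnc1`: 7970 nM
- compound 3, `NC(=O)CCSC(=S)NCc1cccnc1`: 1160 nM

All three were tested in a functional assay on SK-BR-3 cells (Homo sapiens) for cytotoxicity, read by resazurin assay, with a stated time of 72 h; on this read-out lower numbers stand for stronger inhibition and higher numbers for weaker inhibition. Compound 3 gives 1160 nM; this number is indistinguishable from that of compound 1 within the usual scatter, and it stands well apart from compound 2, as a 6.9-fold lower number from compound 2 to compound 3 (0.84 log units; beyond the scatter) shows. The other measured steps also sit on the carbonyl carbon: a 7.1-fold higher number from compound 1 to compound 2 (0.85 log units; beyond the scatter) and a 1.0-fold higher number from compound 1 to compound 3 (0.02 log units; within the scatter).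

Compound 4, `O=C(CCSC(=S)NCc1cccnc1)NCc1ccccc1`, differs from compound 3 by benzyl in place of hydrogen on an amide-type nitrogen. Going by the values given here, none of the measured steps touches this amide-type nitrogen, so none bears directly on the change; they show only that swapping hydroxy for amino or methyl on the carbonyl carbon moved the number, while methyl against amino stayed within the scatter. Among the compounds with values here, with no measured step on the amide nitrogen, the expectation is for no change beyond the scatter. Compound 4 is therefore expected to give 900 nM, with a range from 300 nM to 3000 nM, which means an expected step of a 1.3-fold lower number from compound 3 to compound 4 (0.11 log units; within the scatter).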

Compound 4, half-maximal inhibitory concentration: > 100000 nM
Compound 4: a limit, no number; the forecaster's own chance of this, stated with the estimate: 5%; middle value at least 110-fold (2.04 log units) from the limit.
By their numbers in this assay, from the lowest: compounds 1 and 3 (each within the scatter of the next); then compound 2. At a limit, above all of these: compound 4.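

In this assay, going by these compounds alone, the amide-type nitrogen proves to be a position where a change matters greatly: benzyl in place of hydrogen gives an at least 86-fold higher number from compound 3 to compound 4 (1.93 log units; beyond the scatter), a large step, whereas the earlier steps on the carbonyl carbon were modest or within the scatter. Compound 4 stands at a limit of the assay, > 100000 nM, and this is not a number. The step therefore marks only the smallest size the change can have, and its full size cannot be read: the limit of > 100000 nM in this assay, at which 1 of the 4 values shown sits.

The compounds shown leave open whether any group on this nitrogen has such an effect or whether it takes the whole benzyl group; a small methyl, a directly attached phenyl or a longer chain ending in phenyl would help to separate these cases. What lies behind the step also remains unknown.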